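From methyl to methylamino on a shared core

A few compounds are considered here, and "the series" means these few. Any claim that something is new, unique, unknown or untested is made for them only; others in the source may bear on it.

Among the measured compounds shown here, compound 1 `Cc1ncnc2[nH]cc(Sc3cccs3)c12` gives 38100 nM in a functional assay on HCT-116 cells (Homo sapiens), read by MTT assay, with a stated time of 3 days (a lower number here means a stronger inhibitor, a higher number a weaker inhibitor), the highest of the three numbers measured so far. Compound 2 `COc1ncnc2[nH]cc(Sc3cccs3)c12` gives 17200 nM in this assay, and compound 3 `CN(C)c1ncnc2[nH]cc(Sc3cccs3)c12` gives 11000 nM. The step to compound 4 `CNc1ncnc2[nH]cc(Sc3cccs3)c12` is methylamino in place of methyl on an aromatic carbon. For the measured compounds named here, two measured steps bear on it, since each also replaces the methyl on the same aromatic carbon: a 2.2-fold lower number from compound 1 to compound 2 (0.35 log units; beyond the scatter) and a 3.5-fold lower number from compound 1 to compound 3 (0.54 log units; beyond the scatter). Because a 3.5-fold lower number from compound 1 to compound 3 (0.54 log units; beyond the scatter) came with dimethylamino, which carries the same nitrogen that methylamino brings, a modest step toward a lower number is expected for compound 4, a 2.9-fold lower number from compound 1 to compound 4 (0.47 log units; beyond the scatter). Compound 4 is therefore estimated to give 13000 nM, within a range of 5500 nM to 30000 nM.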

Compound 4, half-maximal inhibitory concentration: 19000 nM
Estimate against measurement, compound 4: 1.5-fold (0.16 log units) below, and the stated range covers the measured number.
By their numbers in this assay, from the lowest: compounds 3, 2, 4 and 1 (each within the scatter of the next, the first and the last beyond it).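

On this aromatic carbon, methylamino does not separate from methyl, with a 2.0-fold lower number from compound 1 to compound 4 (0.30 log units; within the scatter). It also does not separate from its two nearest neighbours, with a 1.7-fold higher number from compound 3 to compound 4 (0.24 log units; within the scatter) and a 1.1-fold higher number from compound 2 to compound 4 (0.04 log units; within the scatter), so removing one methyl from the nitrogen, or exchanging oxygen for nitrogen, leaves no readable change. No measurement here offers an explanation for these numbers. As far as these compounds go, whether a plain amine, a longer chain on the nitrogen or a morpholine ring at this position would move the number beyond the scatter remains open.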